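This account rests on a few compounds, and the source may have more. Where it says the series, first, only, none or still open, it means among the compounds named here.

Measured compounds:
- Compound 1, `CCOC(=O)C(=O)Nc1cccc(OC)c1C#N`: 55.5 mg/kg
- Compound 2, `CCOC(=O)C(=O)Nc1ccc(N(C)C)cc1C#N`: 2.4 mg/kg

Of the compounds shown here, two have been tested in a functional assay on the whole organism with Rattus norvegicus as the target; on this read-out lower numbers stand for an effect already at smaller amounts and higher numbers for an effect only at larger amounts of compound. Compound 1 gives 55.5 mg/kg, the highest of the two numbers in this assay. Compound 2 gives 2.4 mg/kg, a lower number, and the gap between the two is beyond the scatter. These two compounds differ in more than one place, so the gap cannot be assigned to a single change.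

Compound 3, `CCOC(=O)C(=O)Nc1cccc([N+](=O)[O-])c1C#N`, has not yet been tested. It differs from compound 1 in one place: nitro in place of methoxy on an aromatic carbon. For the measured compounds named here, no measured pair shows what happens when a nitro replaces a methoxy on an aromatic carbon, so there is no measured step to lean on. The expected step from compound 1 to compound 3 in this assay, a 1.4-fold lower number from compound 1 to compound 3 (0.14 log units; within the scatter), is therefore small, and may not reach beyond the scatter in either direction. Compound 3 is expected to give about 40 mg/kg, within a range from 10 mg/kg to 160 mg/kg.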

Compound 3, dose for half-maximal effect: 82 mg/kg
The estimate for compound 3 lay 2.1-fold (0.31 log units) below the measured number; the range from low to high includes it.
By their numbers in this assay, from the lowest: compound 2; then compounds 1 and 3 (each within the scatter of the next).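

In this assay, the step of a 1.5-fold higher number from compound 1 to compound 3 (0.17 log units; within the scatter) marks nitro in place of methoxy on this aromatic carbon, ortho to the cyano group, as a change that cannot be told apart from the usual spread of repeated measurements. For this one position and this one swap, the two groups therefore read alike, although they differ in their atoms and in their hydrogen-bond acceptor counts. Nothing available explains this similarity.

What the compounds shown leave open is whether any group at this carbon can move the number beyond the scatter, for example an amine, a carboxylic acid, or a longer alkoxy chain. Going by these compounds, it is also open whether the swap from methoxy to nitro would read the same with a different group elsewhere on the core.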